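The compounds below may be only part of what the source reports. "The series", "measured", "known", "first", "only" and "open" are said of these compounds alone.

Working notes on the series. Two compounds have a number in a functional assay on HepG2 cells (Homo sapiens) for antiproliferative activity, read by CCK-8 assay, with a stated time of 72 h, tested at 8 uM; a lower number here means a weaker effect, a higher number a stronger effect of the compound at the concentration tested. Compound 1 `CC(C)n1cnc2c(Nc3ccccc3)nc(NCOCc3ccc(C(=O)Nc4ccccc4N)cc3)nc21` gives 50.2% in this assay. Compound 2 `Nc1ccccc1NC(=O)c1ccc(Cn2cnc3c(Nc4ccccc4)nc(Cl)nc32)cc1` gives 74.8% in this assay and stands highest of the two numbers; its nearest neighbour is compound 1, which lies lower by a margin beyond the usual scatter. For the measured compounds named here, no pair of measured compounds differs in a single place, so no measured step is available as a guide.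

Compound 3 `CN1CCN(c2nc(Cl)nc3c2ncn3Cc2ccc(C(=O)Nc3ccccc3N)cc2)CC1` is not yet measured. Its difference from compound 2 is 4-methylpiperazin-1-yl in place of anilino on an aromatic carbon. Going by the values given here, with only the two numbers above and no measured step of comparable kind, the direction of this change is open; a moderate decrease from compound 2 is expected, but a result within the scatter of compound 2 would not surprise. The step from compound 2 to compound 3 is estimated at a number 16.8 percentage points lower from compound 2 to compound 3 (beyond the scatter). For compound 3 in this assay an inhibition of 58% is expected, in a range from 30% to 82%.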

Compound 3, a percentage reported as inhibition, at one concentration (the size of the read-out at that concentration, not a potency): 75%
The estimate for compound 3 lay 17 percentage points below the measured number, within the range that was stated.
By their numbers in this assay, from the lowest: compound 1; then compounds 2 and 3 (each within the scatter of the next).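

In this assay the series now has its first single-place step, a number 0.2 percentage points higher from compound 2 to compound 3 (within the scatter), with 4-methylpiperazin-1-yl in place of anilino on the aromatic carbon next to the ring nitrogen. At this one concentration, the read-out therefore does not depend on anilino at this position: a non-aromatic ring with no hydrogen-bond donor serves within the scatter as well as an aromatic carbon ring with one. Nothing measured here explains why the two groups read alike.

Going by these compounds, it remains open whether this holds for other groups at the same position, such as morpholine, a primary amine or a longer alkyl chain. Also open, on these data alone, is how the read-out responds when the chloro group alone gives way to a group such as a methoxy group or a primary amine.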